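A few compounds are considered here, and "the series" means these few. Any claim that something is new, unique, unknown or untested is made for them only; others in the source may bear on it.

Measured compounds in an ADME assay on HEL cells (Homo sapiens) for cytotoxicity, with a stated time of 3 days; a lower number here means that less compound is tolerated, a higher number that more compound is tolerated:

Compound 1 `CCCc1ccc(CCc2cc3cn([C@H]4C[C@H](O)[C@@H](CO)O4)c(=O)nc3o2)cc1` gives > 130000 nM, which is a limit of the assay and not a number.
Compound 2 `CCCCCCc1ccc(-c2cc3cn([C@H]4C[C@H](O)[C@@H](CO)O4)c(=O)nc3o2)nc1` gives > 50000 nM, again a limit and not a number.
Compound 3 `CCCCCCCCCCc1cc2cn([C@H]3C[C@H](O)[C@@H](CO)O3)c(=O)nc2o1` gives > 510000 nM, also a limit and not a number.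

Compound 2 therefore stands at a limit in this assay, as the limit of > 50000 nM in this assay, at which 1 of the 3 values shown sits, records, and the two other values shown are limits as well, the limit of > 130000 nM in this assay, at which 1 of the 3 values shown sits, and (the limit of > 510000 nM in this assay, at which 1 of the 3 values shown sits). No one of the three compounds can be placed above or below another on these numbers.

Going by the values given here, the only step between measured compounds that differ in one place is a step that the two limits leave unreadable from compound 1 to compound 3; the two limits leave it unreadable, so it gives no size to carry forward.

Compound 4 `CCCCCc1ccc(-c2cc3cn([C@H]4C[C@H](O)[C@@H](CO)O4)c(=O)nc3o2)nc1` differs from compound 2 by hydrogen in place of methyl on a saturated chain carbon, five bonds along the chain from an aromatic carbon. No measured step bears on this change, and the one step shown has no readable size. Nothing among the three compounds suggests that compound 4 would be tolerated to a different degree than compound 2 beyond the usual scatter, so compound 4 is expected to sit again at or near a limit, with an expected step that the limit leaves unreadable from compound 2 to compound 4 from compound 2 to compound 4. Compound 4 is estimated at 100000 nM, between 30000 nM and 500000 nM.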

Compound 4, half-maximal cytotoxic concentration: > 50000 nM
Compound 4 was reported as a limit (the forecaster's own chance of this, stated with the estimate: 80%); the middle value lies beyond the limit too.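

In this assay compound 4 gives > 50000 nM, which is a limit and not a number. Compound 2 gives > 50000 nM, also a limit. No step can be read between compound 2 and compound 4. The compounds shown leave open the half-maximal cytotoxic concentration of each, and whether hydrogen in place of methyl changes it at all.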